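Replacing a piperidine with a benzyloxy group on the core

The source may hold more compounds than are shown below. What is called first, only, known or untested is meant among the compounds shown, and "the series" means these compounds.

This account concerns two measured compounds and one that awaits measurement. Compound 1 `CC(C(=O)NCc1ccc(C(F)(F)F)cc1N1CCC(C)(C)CC1)c1ccc(NS(C)(=O)=O)c(F)c1` and compound 2 `Cc1cccc(N2CCN(c3cc(C(F)(F)F)ccc3CNC(=O)C(C)c3ccc(NS(C)(=O)=O)c(F)c3)CC2)c1` share a common core. In an assay on CHO cells for antagonist activity at transient receptor potential cation channel subfamily V member 1 (Homo sapiens), read by FLIPR (on this read-out higher numbers stand for weaker inhibition and lower numbers for stronger inhibition), compound 1 gives 1.3 nM, and in this assay compound 2 gives 1.8 nM; these two values lie within the scatter of each other, so neither can be said to stand apart from the other.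

Compound 3 `CC(C(=O)NCc1ccc(C(F)(F)F)cc1OCc1ccc(F)cc1)c1ccc(NS(C)(=O)=O)c(F)c1` is derived from compound 1 by one change: (4-fluorobenzyl)oxy in place of 4,4-dimethylpiperidin-1-yl on an aromatic carbon. Both the group that leaves and the group that enters carry one hydrogen-bond acceptor and no donor, and the count of heavy atoms is nearly the same. Within the data shown here, no measured pair shows the effect of such a change here, so the expectation rests on the values of compound 1 alone. The step of a 2.3-fold higher number from compound 1 to compound 3 (0.36 log units; beyond the scatter) is expected to be small, at or near the scatter, with slightly weaker inhibition possible. For compound 3 the estimate in this assay is 3 nM, with a range from 0.8 nM to 12 nM.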

Compound 3, inhibition constant: 0.5 nM
Compound 3: middle estimate off by 6.0-fold (0.78 log units), on the high side; the measured number lies below the stated range.
By their numbers in this assay, from the lowest: compound 3; then compounds 1 and 2 (each within the scatter of the next).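

In this assay the exchange of 4,4-dimethylpiperidin-1-yl for (4-fluorobenzyl)oxy gives a 2.6-fold lower number from compound 1 to compound 3 (0.41 log units; beyond the scatter) and so moves inhibition modestly in the stronger direction. This is the first step shown at this position on the shared core, and it shows that the position accepts a six-membered aromatic ring of carbon only, carried on an oxy link, with no loss of inhibition and with a gain that stands beyond the scatter. No measurement shown here bears on the reason for this step.

The compounds shown leave open whether the fluorine of the (4-fluorobenzyl)oxy group takes part in the step, which a plain benzyloxy group would test, and whether the oxygen does, which a benzylamino group would test. They also leave open how a small alkoxy group such as methoxy would read at this place.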